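From bromo to cyano on a shared core

A few compounds are considered here, and "the series" means these few. Any claim that something is new, unique, unknown or untested is made for them only; others in the source may bear on it.

Measured so far in an ADME assay on L6 cells (Rattus norvegicus) for cytotoxicity, read by resazurin assay, with a stated time of 72 h (a lower number here means a stronger inhibitor, a higher number a weaker inhibitor), are these compounds
- compound 1 `OC(c1ccc(Cl)cc1)(c1ccc(Br)cc1)c1cccnc1` gives 57000 nM
- compound 2 `Cc1ccccc1C(O)(c1ccc(Cl)cc1)c1cccnc1` gives 82000 nM
- compound 3 `OC(c1ccc(Br)cc1)(c1ccc(C(F)(F)F)cc1)c1cccnc1` gives 54700 nM

In this assay compound 1 shows no step beyond the scatter to either of the other two measured compounds, so it gives no clear place in any order. The next compound to be measured is compound 4 `N#Cc1ccc(C(O)(c2ccc(Cl)cc2)c2cccnc2)cc1` which keeps the core of compound 1 but has cyano in place of bromo on an aromatic carbon. The count of that change runs cyano in place of bromo on an aromatic carbon and the rest of the structure stays the same.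

Going by the values given here, two measured steps bear on this. The closer in kind is a swap of one group on an aromatic carbon for another, trifluoromethyl in place of chloro, and a 1.0-fold lower number from compound 1 to compound 3 (0.02 log units; within the scatter) is the result. The other replaces the whole 4-bromophenyl with 2-methylphenyl, and a 1.4-fold higher number from compound 1 to compound 2 (0.16 log units; within the scatter) is the result. Among the compounds with values here, both are small, but no measured compound carries cyano, so the data give no direct reading of that group. Going by these two steps, no change beyond the scatter is expected in this assay and no direction can be favoured. The estimated step is a 1.1-fold higher number from compound 1 to compound 4 (0.04 log units; within the scatter) and it remains only an expectation. For compound 4 the estimated value is 62000 nM with an expected range from 35000 nM to 110000 nM in repeat measurements.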

Compound 4, half-maximal inhibitory concentration: > 100000 nM
Compound 4 gave a limit, no number; the forecaster's own chance of this, stated with the estimate: 10%; middle value at least 1.6-fold (0.20 log units) from the limit.
By their numbers in this assay, from the lowest: compounds 3, 1 and 2 (each within the scatter of the next). At a limit, above all of these: compound 4.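

In this assay compound 4 gives a limit and not a number, which makes it the only compound shown without an exact reading: the limit of > 100000 nM in this assay, at which 1 of the 4 values shown sits. Going by these compounds alone, this is the first reading for cyano on this aromatic carbon, para to a large group, and the swap for bromo gives an at least 1.7-fold higher number from compound 1 to compound 4 (0.24 log units; that floor lies within the scatter), a step known only as a floor. Unlike the measured steps from compound 1 to compound 2 and to compound 3, this one is open at its upper end, so the real gap could be small or much larger.

Whether compound 4 truly stands apart from compound 1 by more than the scatter therefore remains unsettled, and an exact number for compound 4 would be needed to decide it. Also open, from the compounds shown here alone, is how an amine, a carboxylic acid or a methoxy group would read at this same place, and whether any group there would give a number clearly apart from that of compound 1.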